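Thiophene gives way to hydroxyphenyl: compound 3 estimated

The compounds below may be only part of what the source reports. "The series", "measured", "known", "first", "only" and "open" are said of these compounds alone.

Compound 1, `CC(=O)N1N=C(c2cc(O)c(O)c([N+](=O)[O-])c2)CC1c1ccoc1`, in an assay on isolated protein for inhibition of Amine oxidase [flavin-containing] A (Homo sapiens), read by fluorescence; a lower number here means a stronger inhibitor, a higher number a weaker inhibitor: 90900 nM
Compound 2, `CC(=O)N1N=C(c2cc(O)c(O)c([N+](=O)[O-])c2)CC1c1cccs1`, in this assay: 86300 nM

For the measured compounds named here, compound 2 holds the lower of the two numbers, but the only measured step, a 1.1-fold lower number from compound 1 to compound 2 (0.02 log units; within the scatter), lies within the scatter, so compound 1 and compound 2 cannot be told apart in this assay. Both are weak inhibitors.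

Compound 3, `CC(=O)N1N=C(c2cc(O)c(O)c([N+](=O)[O-])c2)CC1c1cccc(O)c1`, has not yet been measured. It differs from compound 2 in one place: 3-hydroxyphenyl in place of thiophen-2-yl on a saturated ring carbon.

Going by the values given here, the single measured step swaps one five-membered aromatic ring for another at this same saturated ring carbon and shows no effect beyond the scatter. Among the compounds with values here, no measured pair addresses a six-membered ring or a hydroxyl group at this place, so nothing in the data predicts a shift in either direction. The expectation is therefore a step of a 1.2-fold lower number from compound 2 to compound 3 (0.06 log units; within the scatter), that is, no change beyond the scatter, with a wide range to reflect the absence of any bearing data.

In this assay compound 3 is estimated at 75000 nM, within a range from 25000 nM to 220000 nM.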

Compound 3, half-maximal inhibitory concentration: 87000 nM
Estimate against measurement, compound 3: 1.2-fold (0.06 log units) below; low and high end bracket the measured number.
By their numbers in this assay, from the lowest: compounds 2, 3 and 1 (each within the scatter of the next).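

For the compounds shown here, until compound 3, the only measured step at this saturated ring carbon joined two five-membered aromatic rings. The six-membered aromatic ring of carbon only, with its hydroxyl, now gives a 1.0-fold higher number from compound 2 to compound 3 (0.00 log units; within the scatter) in this assay and, measured against the furan, a 1.0-fold lower number from compound 1 to compound 3 (0.02 log units; within the scatter) in the same assay. Moving to a larger ring and adding a hydrogen-bond donor thus leaves all three compounds indistinguishable in this assay, so this change, unlike the earlier swap of one five-membered ring for another, shows that ring size and a hydroxyl on the ring do not separate these compounds, though nothing available accounts for this flat result.

The three groups shown are all aromatic rings, so it remains open whether any group at this place can move the number beyond the scatter, for instance an amine, a carboxylic acid or a longer chain. Also open, from the compounds shown here alone, is what plain phenyl would give, and whether 2-hydroxyphenyl or 4-hydroxyphenyl would behave like 3-hydroxyphenyl.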